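Exposure of a methylpyridinyl sulfonyl analogue after intravenous dosing

The source may report more compounds than this note shows. Statements on the series, on what has been measured and on what is new or still open speak of the compounds shown alone.

Of the compounds shown here, two have been measured in an ADME assay on the whole organism (plasma, Rattus norvegicus, strain Sprague-Dawley) for pharmacokinetics, read by LC-MS, using cassette dosing, at a dose of 0.2 mg/kg by the intravenous route; on this read-out lower numbers stand for lower exposure and higher numbers for higher exposure at the dose given. Compound 1 `CNCc1cn(S(=O)(=O)c2ccco2)c(-c2cccnc2F)c1F` gives 26 ng.h/mL, and compound 2 `CNCc1cn(S(=O)(=O)c2ccoc2)c(-c2cccnc2F)c1F` gives 41 ng.h/mL. Within the data shown here, the one measured step, a 1.6-fold higher number from compound 1 to compound 2 (0.20 log units; within the scatter), leaves compound 2 with the higher of the two numbers in this assay, though its gap to compound 1 lies within the scatter, so neither can be called the better exposed. Compound 3 `CNCc1cn(S(=O)(=O)c2ccc(C)nc2)c(-c2cccnc2F)c1F` is the next compound; it differs from compound 2 only on the sulfonyl sulfur: 6-methylpyridin-3-yl in place of furan-3-yl on a sulfonyl sulfur. A six-membered aromatic ring with 1 hetero atom thus enters where a five-membered aromatic ring with 1 hetero atom leaves. Among the measured compounds shown here, no measured step exchanges the kind of ring on the sulfonyl sulfur; the single step from compound 1 to compound 2 stayed within the scatter. Compound 3 is therefore expected to show a 1.2-fold lower number from compound 2 to compound 3 (0.07 log units; within the scatter), with a wide range; its estimate in this assay is 35 ng.h/mL between 10 ng.h/mL and 120 ng.h/mL.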

Compound 3, area under the concentration-time curve: 41 ng.h/mL
Compound 3: the middle estimate sits 1.2-fold (0.07 log units) below what was measured; low and high end bracket the measured number.
By their numbers in this assay, from the lowest: compounds 1, 2 and 3 (each within the scatter of the next).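

With 6-methylpyridin-3-yl on the sulfonyl sulfur, this assay gives no change at the digits printed from compound 2 to compound 3 (within the scatter), and the same group in place of furan-2-yl gives a 1.6-fold higher number from compound 1 to compound 3 (0.20 log units; within the scatter). The earlier step only moved the attachment point within a furan, whereas these steps exchange a five-membered aromatic ring for a six-membered one and bring in more heavy atoms, yet all three compounds remain within the scatter of one another at this position. No supporting data bear on why the read-out stays so close across these groups.

As far as these compounds go, it remains open what the methyl group and the ring nitrogen each contribute to the result in compound 3. From the compounds shown here alone, it is also open whether a piperidine ring on the sulfonyl sulfur, or an amine or a carboxylic acid on the pyridine ring, would move the number beyond the scatter.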